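The source may report more compounds than this note shows. Statements on the series, on what has been measured and on what is new or still open speak of the compounds shown alone.

Measured compounds:
compound 1 `O=C1O[C@@H](CO)CN1c1ccc(-n2cc(-c3ccccn3)cn2)c(F)c1` — 59 ug/mL
compound 2 `O=C1O[C@@H](CN2CCCCC2)CN1c1ccc(-n2cc(-c3ccccn3)cn2)c(F)c1` — > 400 ug/mL

Within the data shown here, in an ADME assay on L02 cells (Homo sapiens) for cytotoxicity, read by MTT assay, with a stated time of 48 h (a higher number here means a weaker inhibitor, a lower number a stronger inhibitor), compound 1 gives 59 ug/mL and stands as the only plain number in the set. For compound 2 the value > 400 ug/mL is a limit of the assay and not a number (the limit of > 400 ug/mL in this assay, at which 1 of the 2 values shown sits). Among the measured compounds shown here, the single measured step, an at least 6.7-fold higher number from compound 1 to compound 2 (0.83 log units; beyond the scatter), is the one that bears on the new compound.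

Compound 3 `COC(=O)CC1CCN(C[C@H]2CN(c3ccc(-n4cc(-c5ccccn5)cn4)c(F)c3)C(=O)O2)CC1` differs from compound 1 by 4-((methoxycarbonyl)methyl)piperidin-1-yl in place of hydroxy on a saturated chain carbon bound to a saturated ring carbon. The change keeps the piperidin-1-yl entry of compound 2 and carries a (methoxycarbonyl)methyl group on the ring; the place of the change is the same saturated chain carbon bound to a saturated ring carbon.

Given the size of an at least 6.7-fold higher number from compound 1 to compound 2 (0.83 log units; beyond the scatter), the step in this assay is expected to run in the same direction, toward a weaker inhibitor, and to be of at least modest size; a limit rather than a number is the more likely outcome. Compound 3 is therefore expected to give about 350 ug/mL, within 120 ug/mL to 800 ug/mL. This corresponds to an expected step of a 5.9-fold higher number from compound 1 to compound 3 (0.77 log units; beyond the scatter).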

Compound 3, half-maximal inhibitory concentration: > 400 ug/mL
Compound 3 ended at the assay's limit; the forecaster's own chance of this, stated with the estimate: 65%; at least 1.1-fold (0.05 log units) between middle value and limit.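

Replacing hydroxy with 4-((methoxycarbonyl)methyl)piperidin-1-yl on the saturated chain carbon bound to a saturated ring carbon gives an at least 6.7-fold higher number from compound 1 to compound 3 (0.83 log units; beyond the scatter) in this assay. For compound 3, > 400 ug/mL is a limit of the assay and not a number. The series now shows that a second piperidin-1-yl entry, this one carrying a (methoxycarbonyl)methyl group on its ring, also fails to give a plain number at this place, while the step from compound 2 to compound 3 cannot be read, as both compounds end at the same limit: the limit of > 400 ug/mL in this assay, at which 2 of the 3 values shown sit.

The compounds shown leave open whether the (methoxycarbonyl)methyl group changes the reading at all, since no plain number exists for either piperidin-1-yl compound. Also open, going by these compounds, is whether the same limit is reached with other entries at this place, such as morpholin-4-yl, a simple acyclic amine, or a piperidin-1-yl ring carrying a free carboxylic acid in place of the methyl ester.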